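The compounds below may be only part of what the source reports. "The series", "measured", "known", "first", "only" and "open" are said of these compounds alone.

In an ADME assay on BJ cells (Homo sapiens), read by MTT assay, with a stated time of 72 h (on this read-out higher numbers stand for weaker inhibition and lower numbers for stronger inhibition), the measured compounds are:

- compound 1 `C#Cc1cn([C@@H]2O[C@H](CO)[C@@H](O)[C@H]2O)c2ncnc(N(C)C)c12`: 410 nM
- compound 2 `Cc1ncnc2c1c(-c1cccs1)cn2[C@@H]1O[C@H](CO)[C@@H](O)[C@H]1O`: > 100000 nM, a limit of the assay
- compound 3 `Cc1ncnc2c1c(-c1cc3ccccc3o1)cn2[C@@H]1O[C@H](CO)[C@@H](O)[C@H]1O`: 93900 nM

Of the two values that are numbers and not limits, compound 3 holds the higher. Compound 4 `C#Cc1cn([C@@H]2O[C@H](CO)[C@@H](O)[C@H]2O)c2ncnc(C)c12` differs from compound 3 by one change: ethynyl in place of 1-benzofuran-2-yl on an aromatic carbon. Within the data shown here, the only measured step at this place, an at least 1.0-fold lower number from compound 2 to compound 3 (0.02 log units; that floor lies within the scatter), exchanges one aromatic group for another and says little about ethynyl. Compound 1 also carries ethynyl, though its core differs elsewhere, and gives 410 nM. A clearly lower number is therefore expected in this assay, with the size of the drop uncertain. The expected change is a 47-fold lower number from compound 3 to compound 4 (1.67 log units; beyond the scatter). Compound 4 is estimated at 2000 nM, within an expected range of 200 nM to 30000 nM.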

Compound 4, half-maximal inhibitory concentration: 50 nM
Beside the measured number, compound 4's estimate is 40-fold (1.60 log units) above it; the measured number lies below the stated range.
By their numbers in this assay, from the lowest: compound 4; then compound 1; then compound 3. At a limit, above all of these: compound 2.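

In this assay, ethynyl on this aromatic carbon gives far lower numbers than either aromatic ring group, with a 1900-fold lower number from compound 3 to compound 4 (3.27 log units; beyond the scatter) and an at least 2000-fold lower number from compound 2 to compound 4 (3.30 log units; beyond the scatter). The second step is only a floor, as compound 2 stands at a limit of the assay: the limit of > 100000 nM in this assay, at which 1 of the 4 values shown sits. With ethynyl held constant, the other place on the core also counts, with methyl in place of dimethylamino giving an 8.2-fold lower number from compound 1 to compound 4 (0.91 log units; beyond the scatter). The compounds shown leave open whether the triple bond itself is needed or any small group would do. A nitrile, a vinyl group or a longer alkyne chain at this place would bear on that.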